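Acyl variation at the saturated carbon and plasma half-life

The source may report more compounds than this note shows. Statements on the series, on what has been measured and on what is new or still open speak of the compounds shown alone.

Compound 1 `CC(=O)Oc1ccccc1C(=O)O[C@H]1CO[C@H]2[C@@H]1OC[C@H]2O`: 0.0183 h
Compound 2 `CC(=O)Oc1ccccc1C(=O)O[C@H]1CO[C@H]2[C@@H]1OC[C@H]2OC(=O)c1ccnn1C`: 0.0642 h
Compound 3 `CC(=O)Oc1ccccc1C(=O)O[C@H]1CO[C@H]2[C@@H]1OC[C@H]2OC(=O)c1ccc(O)cc1`: 0.0198 h

In an ADME assay on a cell-free system (plasma, Homo sapiens) for metabolic stability, with Plasma (Rattus norvegicus) as the target, read by HPLC, at pH 7.4 (a lower number here means that the compound disappears faster, a higher number that the compound lasts longer), compound 3 stands second highest of the three, close to compound 1 and well below compound 2 a 3.2-fold lower number from compound 2 to compound 3 (0.51 log units; beyond the scatter). Compound 4 `CC(=O)Oc1ccccc1C(=O)O[C@H]1CO[C@H]2[C@@H]1OC[C@H]2OC(=O)c1ccccc1C` differs from compound 3 by 2-methylphenyl in place of 4-hydroxyphenyl on a carbonyl carbon. The step that bears most on this is the exchange of the acyl group between compound 2 and compound 3, which was modest, and a 3.5-fold higher number from compound 1 to compound 2 (0.55 log units; beyond the scatter) shows that a change of the acyl group on that oxygen can move the half-life beyond the scatter, whereas a 1.1-fold higher number from compound 1 to compound 3 (0.03 log units; within the scatter) did not. Among the measured compounds shown here, no measured step replaces the 4-hydroxyphenyl with a phenyl bearing a methyl, so the direction is uncertain; a modest rise is expected, a 1.6-fold higher number from compound 3 to compound 4 (0.21 log units; within the scatter). Compound 4 is therefore estimated at 0.032 h, within 0.012 h to 0.085 h.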

Compound 4, half-life: 0.0138 h
Beside the measured number, compound 4's estimate is 2.3-fold (0.37 log units) above it; the measured number falls inside the stated range.
By their numbers in this assay, from the lowest: compounds 4, 1 and 3 (each within the scatter of the next); then compound 2.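

Exchanging 4-hydroxyphenyl for 2-methylphenyl on the carbonyl carbon stays within the scatter, a 1.4-fold lower number from compound 3 to compound 4 (0.16 log units; within the scatter), so in this assay the two phenyl groups shown cannot be told apart. The (2-methylphenyl)carbonyl group also stays within the scatter of the free hydroxyl, a 1.3-fold lower number from compound 1 to compound 4 (0.12 log units; within the scatter). The 1-methyl-1H-pyrazol-5-yl group remains the only one shown to stand apart, now also from 2-methylphenyl, a 4.7-fold lower number from compound 2 to compound 4 (0.67 log units; beyond the scatter).

No available evidence explains why this group stands apart. Going by these compounds, it remains open whether an acyl group bearing an amine or a longer saturated chain would follow the phenyl groups or 1-methyl-1H-pyrazol-5-yl.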